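Working notes on three measured compounds and one to follow

The source may report more compounds than this note shows. Statements on the series, on what has been measured and on what is new or still open speak of the compounds shown alone.

Measured so far:
compound 1 `O=C1OC(Cc2nc(Cc3ccccc3)no2)c2ccccc21` — > 10000 nM
compound 2 `O=C1OC(Cc2nc(-c3ccc(Oc4ccccc4)cc3)no2)c2ccccc21` — > 10000 nM
compound 3 `CCCCCCOc1ccc(C(O)C2OC(=O)c3c(OC)cc(OC)cc32)cc1` — 5360 nM

In a functional assay on RAW264.7 cells (Mus musculus) for inhibition, read by Griess assay, with stated times of 1 h and 24 h (on this read-out lower numbers stand for stronger inhibition and higher numbers for weaker inhibition), compound 1 gives > 10000 nM, a limit and not a number. Compound 2 gives > 10000 nM, again a limit. For the measured compounds named here, compound 3 gives 5360 nM, the only number among the three values shown; the other two sit at the limit of > 10000 nM in this assay, at which 2 of the 3 values shown sit. Going by the values given here, no two measured compounds differ in a single place, so no measured step exists to lean on.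

Compound 4 `COc1cc(OC)c2c(c1)C(C(O)c1ccc(OCc3ccccc3)cc1)OC2=O` differs from compound 3 in one place: phenyl in place of pentyl on a saturated chain carbon bound to an oxygen on an aromatic ring. Lacking any measured step, the step of a 1.1-fold lower number from compound 3 to compound 4 (0.03 log units; within the scatter) is expected to be small, with no direction beyond the usual scatter. For compound 4 the estimate in this assay is 5000 nM, within 2000 nM to 15000 nM.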

Compound 4, half-maximal inhibitory concentration: > 10000 nM
Compound 4 was reported as a limit; the forecaster's own chance of this, stated with the estimate: 30%; middle value at least 2.0-fold (0.30 log units) away from the limit.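

In this assay compound 4 gives > 10000 nM, a limit and not a number. Phenyl in place of pentyl gives an at least 1.8-fold higher number from compound 3 to compound 4 (0.27 log units; that floor lies within the scatter), the first measured step in the series, so this position has one readable change, and only its floor is known. Hexyloxy to benzyloxy yields no number at this position, and the series now gathers at the ceiling: the limit of > 10000 nM in this assay, at which 3 of the 4 values shown sit.

As far as these compounds go, the true size of the step stays open. Also open, from the compounds shown here alone, is whether a longer chain or an amine in place of pentyl would give a number rather than a limit.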